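Aroyl Change in a Shared Core: Compound 2 to Compound 3

The compounds below may be only part of what the source reports. "The series", "measured", "known", "first", "only" and "open" are said of these compounds alone.

Compound 1 `CN(C(=O)NC(=O)c1ccccc1F)c1nc(C(F)(F)F)c(C(=O)N/N=C/c2ccccc2C(F)(F)F)s1` gives 10.1 ug/mL in a functional assay on HeLa cells (Homo sapiens) for inhibition, read by MTT assay, with a stated time of 72 h; on this read-out higher numbers stand for weaker inhibition and lower numbers for stronger inhibition.
Compound 2 `CN(C(=O)NC(=O)c1c(F)cccc1F)c1nc(C(F)(F)F)c(C(=O)N/N=C/c2ccccc2C(F)(F)F)s1` gives 19.6 ug/mL in this assay.

Compound 2 holds the highest of the two numbers, and its nearest neighbour is reached by a 1.9-fold higher number from compound 1 to compound 2 (0.29 log units; within the scatter). Compound 3 `CN(C(=O)NC(=O)c1ccc(C(F)(F)F)cc1)c1nc(C(F)(F)F)c(C(=O)N/N=C/c2ccccc2C(F)(F)F)s1` differs from compound 2 in one place: 4-(trifluoromethyl)phenyl in place of 2,6-difluorophenyl on a carbonyl carbon. Among the compounds with values here, the only measured step, a 1.9-fold higher number from compound 1 to compound 2 (0.29 log units; within the scatter), concerns a smaller edit of the same aroyl group and was within the scatter, so it bears on the present change only loosely. Compound 3 is therefore expected to show no step beyond the scatter, a 1.3-fold lower number from compound 2 to compound 3 (0.12 log units; within the scatter). The estimate for compound 3 is 15 ug/mL, expected to fall between 5 ug/mL and 45 ug/mL.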

Compound 3, half-maximal inhibitory concentration: 3.76 ug/mL
The estimate for compound 3 lay 4.0-fold (0.60 log units) above the measured number; the whole stated range lies above it.
By their numbers in this assay, from the lowest: compound 3; then compounds 1 and 2 (each within the scatter of the next).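

In this assay, this aroyl position shows its first change beyond the scatter: 4-(trifluoromethyl)phenyl in place of 2,6-difluorophenyl on the carbonyl carbon gives a 5.2-fold lower number from compound 2 to compound 3 (0.72 log units; beyond the scatter) in this series. Replacing 2-fluorophenyl gives a 2.7-fold lower number from compound 1 to compound 3 (0.43 log units; beyond the scatter) as well, so compound 3 shows the strongest inhibition of the three, and the two fluorophenyl compounds remain within the scatter of each other. Going by these compounds, whether 4-methoxyphenyl or 4-cyanophenyl on the same carbonyl carbon would match compound 3 stays open. Nothing available here accounts for the lower number of compound 3.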